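The source may report more compounds than this note shows. Statements on the series, on what has been measured and on what is new or still open speak of the compounds shown alone.

Of the compounds shown here, three have been tested so far in an ADME assay on MT4 cells (Homo sapiens) for cytotoxicity, read by MTT assay, with a stated time of 5 days; on this read-out higher numbers stand for lower toxicity in this test and lower numbers for higher toxicity in this test. Compound 3 `Clc1ccc(-c2nnc(-c3cccnc3)n2Nc2nc3ccc(Br)cc3s2)cc1` gives 29.6 ug/mL, the second highest of the three numbers. Its nearest neighbour is compound 1 `COc1ccc2nc(Nn3c(-c4ccc([N+](=O)[O-])cc4)nnc3-c3cccnc3)sc2c1`, which in this assay gives 12.9 ug/mL; the furthest is compound 2 `Fc1ccc2nc(Nn3c(-c4ccc(Cl)cc4)nnc3-c3cccnc3)sc2c1`, which gives 92.9 ug/mL. The one step already measured among these runs from the fluoro compound to the bromo compound: a 3.1-fold lower number from compound 2 to compound 3 (0.50 log units; beyond the scatter).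

Compound 4 `COc1ccc2nc(Nn3c(-c4ccc(Cl)cc4)nnc3-c3cccnc3)sc2c1` differs from compound 3 in one place: methoxy in place of bromo on an aromatic carbon. For the measured compounds named here, no measured step swaps a halogen for a methoxy group, so the halogen step offers only indirect guidance. Compound 1 carries a methoxy group on its fused ring system and sits lowest of the three, yet it also differs from compound 4 elsewhere, so its value is a hint rather than a step. The expectation is therefore for a modest move downward, a 1.5-fold lower number from compound 3 to compound 4 (0.17 log units; within the scatter). Compound 4 is estimated to give 20 ug/mL in this assay, with a likely range from 8 ug/mL to 50 ug/mL.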

Compound 4, half-maximal cytotoxic concentration: 66.9 ug/mL
The estimate for compound 4 lay 3.3-fold (0.52 log units) below the measured number, and the stated range ends below it.
By their numbers in this assay, from the lowest: compound 1; then compound 3; then compounds 4 and 2 (each within the scatter of the next).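

In this assay the position on the fused ring system now holds three groups on an otherwise unchanged molecule, and bromo is the one that stands apart: the swap to methoxy gives a 2.3-fold higher number from compound 3 to compound 4 (0.35 log units; beyond the scatter) while fluoro and methoxy compare as a 1.4-fold lower number from compound 2 to compound 4 (0.14 log units; within the scatter) and cannot be separated. Methoxy at this position therefore does not go with a low number by itself, and keeping it while placing chloro where nitro stood gives a 5.2-fold higher number from compound 1 to compound 4 (0.71 log units; beyond the scatter) on the same core. Nothing available explains why bromo differs from the other two groups.

From the compounds shown here alone, how an amine or a carboxylic acid would read at this position stays open. So does whether the change from nitro to chloro would be of the same size with fluoro or bromo on the fused ring system.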